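Urea partners on a shared core

A few compounds are considered here, and "the series" means these few. Any claim that something is new, unique, unknown or untested is made for them only; others in the source may bear on it.

Measured compounds:
compound 1 `O=C(Nc1ccc(Cl)cc1)Nc1ccc(Nc2ncnc3c2OCCN3)cc1` — > 10000 nM
compound 2 `Cc1ccc(F)c(NC(=O)Nc2ccc(Nc3ncnc4c3OCCN4)cc2)c1` — 7000 nM
compound 3 `O=C(Nc1ccc(Nc2ncnc3c2OCCN3)cc1)Nc1cccc2ccccc12` — > 10000 nM

In an assay on isolated protein for inhibition of proto-oncogene tyrosine-protein kinase receptor Ret variant V804L (Homo sapiens), read by 33P incorporation, with stated times of 15 min and 40 min (on this read-out higher numbers stand for weaker inhibition and lower numbers for stronger inhibition), compound 3 reaches only the limit of the test, > 10000 nM, so its true number is not known. Compound 1 also sits at that limit, > 10000 nM. Compound 2 gives a real number, 7000 nM, and the step of an at least 1.4-fold higher number from compound 2 to compound 3 (0.15 log units; that floor lies within the scatter) is small enough to fall within ordinary scatter, while a step that the two limits leave unreadable from compound 1 to compound 3 cannot be read at all, because of the limit of > 10000 nM in this assay, at which 2 of the 3 values shown sit.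

Compound 4 `CC(C)(C)c1csc(NC(=O)Nc2ccc(Nc3ncnc4c3OCCN4)cc2)n1` differs from compound 3 by one change: 4-(tert-butyl)-1,3-thiazol-2-yl in place of naphthalen-1-yl on an amide-type nitrogen. Among the measured compounds shown here, only the steps among compounds 1, 2 and 3 can guide the expectation, and all of them replace one aryl group on that urea nitrogen with another without moving the number far. A similar outcome is therefore expected for compound 4, a step of an at least 1.2-fold lower number from compound 3 to compound 4 (0.09 log units; that floor lies within the scatter) in this assay, with a good chance that only a limit is returned again. Compound 4 is estimated at 8000 nM, within 2000 nM to 30000 nM.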

Compound 4, half-maximal inhibitory concentration: > 10000 nM
Compound 4: a limit, no number; the forecaster's own chance of this, stated with the estimate: 50%; middle value at least 1.2-fold (0.09 log units) away from the limit.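

In this assay compound 4 gives > 10000 nM, which is a limit of the assay and not a number. Among the compounds shown here, this shows that a five-membered aromatic ring with 2 hetero atoms, carrying a tert-butyl group, also fails to bring a clear gain on this amide-type nitrogen, and the one readable comparison is an at least 1.4-fold higher number from compound 2 to compound 4 (0.15 log units; that floor lies within the scatter). The steps to compound 4 from compound 1 and compound 3 cannot be read, because both ends of each step are limits: the limit of > 10000 nM in this assay, at which 3 of the 4 values shown sit.

The compounds shown leave open whether a partner of another kind on this nitrogen, such as a pyridine ring or a chain ending in an amine, would give a number well clear of the limit. They also leave open how compound 1, compound 3 and compound 4 truly rank against one another.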